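The source may report more compounds than this note shows. Statements on the series, on what has been measured and on what is new or still open speak of the compounds shown alone.

Measured so far:
- compound 1 `N#Cc1c(-c2ccc(Br)cc2)nc2cnccc2c1NCC(N)=O` — 1.9
- compound 2 `CC[C@@H](Nc1c(C#N)c(-c2ccc(-c3cccc(CO)c3)cc2)nc2cnccc12)C(N)=O` — 2

Both measurements come from a physicochemical assay for lipophilicity, read by HPLC, at pH 7.5; a higher number here means a more lipophilic compound, a lower number a more polar compound. In this assay compound 1 gives 1.9, and compound 2 gives 2. Compound 2 holds the higher of the two numbers, but its nearest neighbour, compound 1, sits only a little lower, and that gap lies within the usual scatter of repeated measurements, so the two compounds cannot be told apart on this measurement. Among the compounds with values here, compound 1 and compound 2 differ in more than one place, so no single step between them has been worked out.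

Compound 3 `CC[C@@H](Nc1c(C#N)c(-c2ccc(-c3ccc(OC)cc3)cc2)nc2cnccc12)C(N)=O` has not yet been measured. It keeps the core of compound 2 and differs from it at one position: 4-methoxyphenyl in place of 3-(hydroxymethyl)phenyl on an aromatic carbon

Within the data shown here, with no measured single step to lean on, the expectation for compound 3 rests on the structural change alone. The step from compound 2 to compound 3 is expected to be upward and beyond the scatter, about a number 0.80 log units higher from compound 2 to compound 3 (beyond the scatter). For compound 3 in this assay the estimate is 2.8, expected to fall between 2.3 and 3.3.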

Compound 3, distribution coefficient: 2.7
Estimate against measurement, compound 3: 0.10 log units above, within the range that was stated.
By their numbers in this assay, from the lowest: compounds 1 and 2 (each within the scatter of the next); then compound 3.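

In this assay, within the data shown here, putting 4-methoxyphenyl in place of 3-(hydroxymethyl)phenyl on an aromatic carbon gives the first step at this position that can be read, a number 0.70 log units higher from compound 2 to compound 3 (beyond the scatter). The two groups have the same number of heavy atoms, the same atoms and the same count of hydrogen-bond acceptors, so this position can move the number even when the atoms stay the same; the differences are that the leaving group has a hydrogen-bond donor, the entering group has none, and the oxygen-bearing group is arranged differently on the ring. Nothing measured here explains the step.

Among these compounds, the single step changes the donor count and the arrangement together, so it remains open how much of the rise belongs to either. Also open, as far as these compounds go, is how a phenyl ring carrying an amine or a carboxylic acid at this position would read in this assay, and whether the step would be the same size on a different core.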